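Aryl Replacement on the Shared Core and Antiproliferative Potency

The source may report more compounds than this note shows. Statements on the series, on what has been measured and on what is new or still open speak of the compounds shown alone.

Compound 1 `N#CC1=C(N)N(c2ccc(S(N)(=O)=O)cc2)C2=C(C(=O)CCC2)C1c1ccc(O)cc1` carries a 4-hydroxyphenyl group on a saturated ring carbon of the shared core. In a functional assay on Ehrlich cells (Mus musculus) for antiproliferative activity, read by trypan blue exclusion, with a stated time of 2 h (on this read-out higher numbers stand for weaker inhibition and lower numbers for stronger inhibition), compound 1 gives 3 ug/mL, the lowest of the two numbers recorded. Compound 2 `COc1cc(CC2C(C#N)=C(N)N(c3ccc(S(N)(=O)=O)cc3)C3=C2C(=O)CCC3)ccc1O` differs from it by a 4-hydroxy-3-methoxybenzyl in place of 4-hydroxyphenyl on a saturated ring carbon, and in this assay compound 2 gives 25 ug/mL; the step of an 8.3-fold higher number from compound 1 to compound 2 (0.92 log units; beyond the scatter) shows weaker inhibition.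

Compound 3 `COc1ccc(C2C(C#N)=C(N)N(c3ccc(S(N)(=O)=O)cc3)C3=C2C(=O)CCC3)c2ccccc12` is not yet measured. Its change from compound 1 is 4-methoxynaphthalen-1-yl in place of 4-hydroxyphenyl on a saturated ring carbon. For the measured compounds named here, the only measured step that bears on it is an 8.3-fold higher number from compound 1 to compound 2 (0.92 log units; beyond the scatter), which touched the same saturated ring carbon and weakened inhibition modestly. A weakening of similar size, beyond the scatter, is therefore expected here, namely a 4.0-fold higher number from compound 1 to compound 3 (0.60 log units; beyond the scatter). Compound 3 is accordingly estimated at 12 ug/mL, with a range from 4 ug/mL to 40 ug/mL.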

Compound 3, half-maximal inhibitory concentration: 70 ug/mL
Compound 3: the middle estimate sits 5.8-fold (0.77 log units) below what was measured; the whole stated range lies below it.
By their numbers in this assay, from the lowest: compound 1; then compound 2; then compound 3.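

At this saturated ring carbon, 4-methoxynaphthalen-1-yl costs far more than the earlier benzyl change did: this assay records a 23-fold higher number from compound 1 to compound 3 (1.37 log units; beyond the scatter) and a large step, where the earlier step was modest. The new group also falls behind 4-hydroxy-3-methoxybenzyl, with a 2.8-fold higher number from compound 2 to compound 3 (0.45 log units; beyond the scatter) and weaker inhibition again, so both replacements of 4-hydroxyphenyl shown here weaken inhibition and neither goes against that pattern. The entering group differs from 4-hydroxyphenyl in having 2 six-membered aromatic rings and 0 hydrogen-bond donors, but no supporting data connect the loss to either difference.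

The compounds shown leave open whether the second aromatic ring or the methoxy group in place of the hydroxyl accounts for the loss, a question that 4-hydroxynaphthalen-1-yl and 4-methoxyphenyl on the same carbon would separate. They also leave open whether a 4-aminophenyl or 4-carboxyphenyl group there would match compound 1.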